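Methyl for chloro on the benzyl arm: compound 4

The compounds below may be only part of what the source reports. "The series", "measured", "known", "first", "only" and "open" are said of these compounds alone.

Measured so far in an in vitro functional assay on cells for agonist activity at Bombesin receptor subtype-3 (Mus musculus), read by luminescence and calcium flux; on this read-out higher numbers stand for an effect only at larger amounts of compound and lower numbers for an effect already at smaller amounts:
- compound 1, `CCCCc1cnc(Cc2ccc(-c3ccccc3C(=O)O)cc2)[nH]1`: > 10000 nM, a limit of the assay and not a number
- compound 2, `CCCCc1cnc(CCCc2ccc(-c3ccccc3C(=O)O)cc2)[nH]1`: 382 nM
- compound 3, `O=C(O)c1ccccc1-c1ccc(CCc2ncc(Cc3ccc(Cl)cc3)[nH]2)cc1`: 102 nM

Compound 3 stands lowest of the two numbers in this assay. Its nearest neighbour is compound 2, whose number is higher by a step beyond the usual scatter. Compound 1 gives only a limit in this assay; this is the limit of > 10000 nM in this assay, at which 1 of the 3 values shown sits. Going by the values given here, no two of the measured compounds differ in a single place, so no measured step is at hand for the series.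

Compound 4, `Cc1ccc(Cc2cnc(CCc3ccc(-c4ccccc4C(=O)O)cc3)[nH]2)cc1`, is compound 3 with one change: methyl in place of chloro on an aromatic carbon. Both groups are single heavy atoms on the same aromatic carbon, neither adds a donor, an acceptor or a charge. Nothing measured here speaks to the size of such an exchange, so the expectation is a step in this assay of no more than the scatter, in either direction, with compound 3 as the anchor.

Compound 4 is therefore estimated at 150 nM in this assay, with a range from 40 nM to 600 nM. The expected step from compound 3 is a 1.5-fold higher number from compound 3 to compound 4 (0.17 log units; within the scatter).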

Compound 4, half-maximal effective concentration: 162 nM
For compound 4 the middle estimate is 1.1-fold (0.03 log units) below the measured one; the measured number falls inside the stated range.
By their numbers in this assay, from the lowest: compounds 3 and 4 (each within the scatter of the next); then compound 2. At a limit, above all of these: compound 1.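

In this assay, methyl in place of chloro, para to a large group, gives a 1.6-fold higher number from compound 3 to compound 4 (0.20 log units; within the scatter). Going by these compounds alone, this is the first step that changes one place only, and it shows that this aromatic carbon tolerates the exchange: in this read-out, 4-methylbenzyl serves as well as 4-chlorobenzyl, so chloro is not needed there for a number of this order. The two groups are equal in heavy-atom count and add no donor, acceptor or charge, and no measurement shown gives a reason for the two numbers lying within the scatter of each other.

Open, going by these compounds, is how far this tolerance extends, whether to a hydroxyl, an amine or a nitrile on the same aromatic carbon, or to plain hydrogen there, which would show whether the para group contributes at all. Also open, on these data alone, are the length of the chain to the core, read on its own with the benzyl arm held fixed, and whether an amide or a tetrazole can take the place of the carboxylic acid.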